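A Second Chloro on the Phenyl of Compound 2

A few compounds are considered here, and "the series" means these few. Any claim that something is new, unique, unknown or untested is made for them only; others in the source may bear on it.

Compound 1, `CC(C)c1ccc(-n2nc(-c3ccc(C(F)(F)F)cc3O)nc2-c2ccccc2O)cc1`: 69.7%
Compound 2, `Oc1cc(C(F)(F)F)ccc1-c1nc(-c2ccccc2O)n(-c2ccc(Cl)cc2)n1`: 68%
Compound 3, `COc1cccc(-n2nc(-c3ccc(C(F)(F)F)cc3O)nc2-c2ccccc2O)c1`: 68.3%

In a functional assay on PC-12 cells (Rattus norvegicus) for cytotoxicity, read by MTT assay, with stated times of 2 h and 24 h, tested at 1 uM (on this read-out higher numbers stand for a stronger effect at the one concentration tested and lower numbers for a weaker effect), compound 2 sits at the low end of three numbers that all lie within the scatter of one another, as the steps show: a number 1.7 percentage points lower from compound 1 to compound 2 (within the scatter) and a number 0.3 percentage points higher from compound 2 to compound 3 (within the scatter). Compound 4, `Oc1cc(C(F)(F)F)ccc1-c1nc(-c2ccccc2O)n(-c2ccc(Cl)cc2Cl)n1`, differs from compound 2 by chloro in place of hydrogen on an aromatic carbon. Among the compounds with values here, no measured step adds a group to this ring; the nearest comparisons are the two steps just given, in which exchanging the whole group on the aromatic nitrogen moved nothing beyond the scatter. A step beyond the scatter is therefore not expected from compound 2 to compound 4, so the expected change is no change at the digits printed from compound 2 to compound 4 (within the scatter). Compound 4 is estimated at 68%, between 59% and 77%.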

Compound 4, a percentage reported as activity, at one concentration (the size of the read-out at that concentration, not a potency): 69%
For compound 4 the middle estimate is 1 percentage points below the measured one, within the range that was stated.
By their numbers in this assay, from the lowest: compounds 2, 3, 4 and 1 (each within the scatter of the next).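

In this assay, within the data shown here, the first added group on this ring, a chloro ortho to a large group, stays within the scatter (a number 1 percentage points higher from compound 2 to compound 4 (within the scatter)). The 2,4-dichlorophenyl group also stays within the scatter of the 3-methoxyphenyl and 4-isopropylphenyl groups on the aromatic nitrogen (a number 0.7 percentage points higher from compound 3 to compound 4 (within the scatter); a number 0.7 percentage points lower from compound 1 to compound 4 (within the scatter)). Nothing available explains why these numbers lie so close.

On these data alone, whether a different group at this position, such as an amine or a carboxylic acid, would give a step beyond the scatter remains open.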